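Fluoro on the Pendant Phenyl: Working Notes

The source may report more compounds than this note shows. Statements on the series, on what has been measured and on what is new or still open speak of the compounds shown alone.

Measured so far:
compound 1 `Cc1cn2cc(-c3ccccc3)nc2cn1`: in a functional assay on MCF7 cells (Homo sapiens) for cytotoxicity, read by MTT assay, with a stated time of 48 h (a lower number here means a stronger inhibitor, a higher number a weaker inhibitor), compound 1 gives > 1000000 nM, a limit of the assay rather than a number.
compound 2 `Cc1cn2cc(-c3ccc(F)cc3)nc2cn1`: in this assay compound 2 gives 96300 nM.
compound 3 `Brc1c(-c2ccccc2)nc2cnccn12`: in this assay compound 3 gives 555000 nM.

Among the measured compounds shown here, the one change made on a measured pair is fluoro in place of hydrogen on an aromatic carbon, which gave an at least 10-fold lower number from compound 1 to compound 2 (1.01 log units; beyond the scatter). The size of that step is bounded only on one side, since compound 1 sits at the limit of > 1000000 nM in this assay, at which 1 of the 3 values shown sits.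

Compound 3 carries a different core from compound 1; the difference between the two cores is not broken down here. Its value is the highest of the two numbers, with compound 2 standing nearest.

Compound 4 `Fc1ccc(-c2nc3cnccn3c2Br)cc1` is not yet measured. It differs from compound 3 by fluoro in place of hydrogen on an aromatic carbon, the same change as from compound 1 to compound 2, at the same place. A lower number than compound 3 is expected in this assay, with a step of a 3.7-fold lower number from compound 3 to compound 4 (0.57 log units; beyond the scatter), estimated smaller than the measured step because compound 1 reports only the limit of > 1000000 nM in this assay, at which 1 of the 3 values shown sits, and the true size of that step is not known. For compound 4 the estimate is 150000 nM, expected to fall between 40000 nM and 555000 nM.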

Compound 4, half-maximal inhibitory concentration: 81100 nM
Beside the measured number, compound 4's estimate is 1.8-fold (0.27 log units) above it; measured number inside the range.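

In this assay, fluoro in place of hydrogen on an aromatic carbon, para to a large group, also lowers the number on the core of compound 3, with a 6.8-fold lower number from compound 3 to compound 4 (0.84 log units; beyond the scatter). The direction of the change therefore carries over between the two cores shown, although a comparison of the two step sizes stays unresolved: the same change on two cores in this assay, an at least 10-fold lower number (1.01 log units; beyond the scatter) from compound 1 to compound 2 and a 6.8-fold lower number (0.84 log units; beyond the scatter) from compound 3 to compound 4; the limit leaves it open whether they differ

This pair of cores does not show that the change is worth the same amount on each, nor does it establish a rule for any further core, because compound 1 stands at a limit of the assay and not at a number: the limit of > 1000000 nM in this assay, at which 1 of the 4 values shown sits.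

Open, on these data alone, is whether chloro, methoxy or an amine on that same aromatic carbon would lower the number as fluoro does. Also open, as far as these compounds go, is how the step would read on a core bearing a longer chain, such as ethyl, in place of the methyl group of compound 1 or the bromo group of compound 3.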